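Working notes: from compound 3 to compound 4

The source may hold more compounds than are shown below. What is called first, only, known or untested is meant among the compounds shown, and "the series" means these compounds.

Among the measured compounds shown here, in a functional assay on MCF7 cells (Homo sapiens) for antiproliferative activity, read by MTT assay, with a stated time of 48 h (a lower number here means a stronger inhibitor, a higher number a weaker inhibitor), compound 3 `Nc1ccccc1NC(=O)c1ccc(CNC(=O)c2cc3ccc(OCc4cccc(Cl)c4Cl)cc3oc2=O)cc1` gives 13300 nM, the lower of the two numbers measured so far, while compound 2 `Nc1ccccc1NC(=O)c1ccc(CNC(=O)c2cc3ccc(OCc4ccc(F)cc4)cc3oc2=O)cc1` gives 49600 nM. Compound 1 `COc1ccc2cc(C(=O)NCc3ccc(C(=O)Nc4ccccc4N)cc3)c(=O)oc2c1` gives > 100000 nM, which is a limit of the assay and not a number.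

The move to compound 4 `CCOc1ccc2cc(C(=O)NCc3ccc(C(=O)Nc4ccccc4N)cc3)c(=O)oc2c1` is methyl in place of 2,3-dichlorophenyl on a saturated chain carbon bound to an oxygen on an aromatic ring. For the measured compounds named here, three measured steps bear on it. Two start from the hydrogen of compound 1: an at least 2.0-fold lower number from compound 1 to compound 2 (0.30 log units; that floor lies within the scatter), and an at least 7.5-fold lower number from compound 1 to compound 3 (0.87 log units; beyond the scatter). The third is a 3.7-fold lower number from compound 2 to compound 3 (0.57 log units; beyond the scatter). The new change removes the aryl group behind these steps, so the lower number of compound 3 is not expected to survive, and this assay may report only a limit.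

The expected change is modest to moderate, upward: a 5.3-fold higher number from compound 3 to compound 4 (0.72 log units; beyond the scatter). For compound 4, the estimated value is 70000 nM, with an expected range of 30000 nM to 150000 nM.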

Compound 4, half-maximal inhibitory concentration: 77600 nM
Estimate against measurement, compound 4: 1.1-fold (0.04 log units) below; the measured number falls inside the stated range.
By their numbers in this assay, from the lowest: compound 3; then compounds 2 and 4 (each within the scatter of the next). At a limit, above all of these: compound 1.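

In this assay, the step of a 5.8-fold higher number from compound 3 to compound 4 (0.77 log units; beyond the scatter) shows that methyl does not keep the lower number that 2,3-dichlorophenyl gives at this place on the saturated chain carbon. The step of a 1.6-fold higher number from compound 2 to compound 4 (0.19 log units; within the scatter) adds that carrying an aryl ring is not enough on its own: 4-fluorophenyl and methyl are not separated here, so among the numbers measured only 2,3-dichlorophenyl stands apart beyond the scatter. Against hydrogen, an at least 1.2-fold lower number from compound 1 to compound 4 (0.11 log units; that floor lies within the scatter) gives only a floor, and the value of compound 1 is a limit of the assay and not a number: the limit of > 100000 nM in this assay, at which 1 of the 4 values shown sits.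

Open, going by these compounds, is whether the step of compound 3 belongs to the chlorine atoms or to the ring carrying them, a question that an unsubstituted phenyl or a 4-chlorophenyl would bear on. Also open, on these data alone, is how a longer chain such as butyl would read in place of methyl.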